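Replacing fluoro with bromo and methoxy on one ring

This account rests on a few compounds, and the source may have more. Where it says the series, first, only, none or still open, it means among the compounds named here.

- compound 1 `COc1cc(C=C(C(=O)/C=C/c2cccc(OC)c2OC)C(=O)/C=C/c2cccc(OC)c2OC)ccc1O`: 430 nM
- compound 2 `COc1cc(OC)c(C=C(C(=O)/C=C/c2cccc(OC)c2OC)C(=O)/C=C/c2cccc(OC)c2OC)c(OC)c1`: 840 nM
- compound 3 `COc1cccc(/C=C/C(=O)C(=Cc2ccc(O)c(F)c2)C(=O)/C=C/c2cccc(OC)c2OC)c1OC`: 330 nM

All three values come from a functional assay on SW480 cells (Homo sapiens) for antiproliferative activity, read by sulforhodamine B assay, with a stated time of 48 h; on this read-out lower numbers stand for stronger inhibition and higher numbers for weaker inhibition. On these numbers, compound 3 at 330 nM cannot be separated from its nearest neighbour: the data show a 1.3-fold lower number from compound 1 to compound 3 (0.11 log units; within the scatter). It does stand apart from the furthest value, with a 2.5-fold lower number from compound 2 to compound 3 (0.41 log units; beyond the scatter).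

The next compound, compound 4 `COc1cc(C=C(C(=O)/C=C/c2cccc(OC)c2OC)C(=O)/C=C/c2cccc(OC)c2OC)cc(Br)c1O`, differs from compound 3 in one group, on a double-bonded chain carbon bound to a double-bonded chain carbon: 3-bromo-4-hydroxy-5-methoxyphenyl in place of 3-fluoro-4-hydroxyphenyl on a double-bonded chain carbon bound to a double-bonded chain carbon.

All three measured steps change this same ring group. Besides the two steps above, the data show a 2.0-fold higher number from compound 1 to compound 2 (0.29 log units; within the scatter). The largest of the three is modest, and the other two lie within the scatter. For the measured compounds named here, the incoming group keeps a hydroxy and a methoxy, both also present in compound 1 at 430 nM, but no measured compound carries bromine, so its contribution is unknown.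

A large change therefore seems unlikely in this assay, and the expected step is a 1.2-fold higher number from compound 3 to compound 4 (0.08 log units; within the scatter), which is no clear shift. For compound 4, the estimated value is 400 nM, with an expected range of 180 nM to 900 nM.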

Compound 4, half-maximal inhibitory concentration: 260 nM
For compound 4 the middle estimate is 1.5-fold (0.19 log units) above the measured one; low and high end bracket the measured number.
By their numbers in this assay, from the lowest: compounds 4, 3, 1 and 2 (each within the scatter of the next, the first and the last beyond it).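

Putting bromo in place of hydrogen on an aromatic carbon gives a 1.7-fold lower number from compound 1 to compound 4 (0.22 log units; within the scatter) in this assay, and exchanging the whole 3-fluoro-4-hydroxyphenyl group for 3-bromo-4-hydroxy-5-methoxyphenyl gives a 1.3-fold lower number from compound 3 to compound 4 (0.10 log units; within the scatter), so this position accepts a bromine-bearing ring with no change that can be told from the scatter. Against 2,4,6-trimethoxyphenyl, the new group gives a 3.2-fold lower number from compound 2 to compound 4 (0.51 log units; beyond the scatter), which makes it the second ring group, after 3-fluoro-4-hydroxyphenyl, to stand apart from compound 2, although compound 1, with its 4-hydroxy-3-methoxyphenyl group, does not. Nothing available here explains why these ring groups give the numbers they do.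

It remains open whether bromo alone, without the methoxy, would give a similar number, and whether the hydroxy contributes when the bromo is present, since no compound shown has a bromine-bearing ring without it. An amine or a carboxylic acid on this ring is also untested among these compounds, and the two other ring groups stay the same throughout, so these results say nothing about changing them.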